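This account rests on a few compounds, and the source may have more. Where it says the series, first, only, none or still open, it means among the compounds named here.

For the measured compounds named here, compound 3 `O=C(COc1ccc(Oc2ccccc2)cc1)Cn1ncc2cc([N+](=O)[O-])ccc21` stands lowest of the three numbers so far in an assay on microsomes from brain for inhibition of Fatty-acid amide hydrolase 1 (Rattus norvegicus), read by fluorescence and HPLC, with a stated time of 45 min (on this read-out higher numbers stand for weaker inhibition and lower numbers for stronger inhibition), giving 550 nM. Compound 1 `O=C(COc1ccc(Oc2ccccc2)cc1)Cn1ncc2ccccc21` gives 2600 nM and compound 2 `CC(=O)Nc1ccc2c(cnn2CC(=O)COc2ccc(Oc3ccccc3)cc2)c1` gives 3900 nM; the gap a 1.5-fold higher number from compound 1 to compound 2 (0.18 log units; within the scatter) sits within the scatter, while a 4.7-fold lower number from compound 1 to compound 3 (0.67 log units; beyond the scatter) and a 7.1-fold lower number from compound 2 to compound 3 (0.85 log units; beyond the scatter) both go beyond it. Compound 4 `CS(=O)(=O)NC(=O)c1ccc2c(cnn2CC(=O)COc2ccc(Oc3ccccc3)cc2)c1` carries (methylsulfonyl)carbamoyl in place of nitro on an aromatic carbon. The step bearing on this is a 7.1-fold lower number from compound 2 to compound 3 (0.85 log units; beyond the scatter), where acetamido gave way to nitro; the new group, like acetamido, brings a hydrogen-bond donor, so reversing that direction is expected to cost roughly as much as compound 2 lost. Compound 4 is therefore expected at 3000 nM, range 1000 nM to 9000 nM, an expected step of a 5.5-fold higher number from compound 3 to compound 4 (0.74 log units; beyond the scatter).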

Compound 4, half-maximal inhibitory concentration: 770 nM
Compound 4: middle estimate off by 3.9-fold (0.59 log units), on the high side, outside the stated range (below it).
By their numbers in this assay, from the lowest: compounds 3 and 4 (each within the scatter of the next); then compounds 1 and 2 (each within the scatter of the next).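

In this assay, (methylsulfonyl)carbamoyl and nitro cannot be told apart on this aromatic carbon (a 1.4-fold higher number from compound 3 to compound 4 (0.15 log units; within the scatter)), so a hydrogen-bond donor in the group does not by itself bring the number back to that of acetamido (a 5.1-fold lower number from compound 2 to compound 4 (0.70 log units; beyond the scatter)). The new group also stands clear of hydrogen (a 3.4-fold lower number from compound 1 to compound 4 (0.53 log units; beyond the scatter)), which nitro alone had shown so far. Nothing measured here accounts for the split between acetamido and (methylsulfonyl)carbamoyl. Open, from the compounds shown here alone, is whether a carboxylic acid or an amine at this place stays level with compound 3 and compound 4. Also open, going by these compounds, is whether a longer chain in place of the methyl of the new group shifts the number.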